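The compounds below may be only part of what the source reports. "The series", "measured", "known", "first", "only" and "open" are said of these compounds alone.

Measured compounds:
compound 1 `O=C(NNc1cccc(Cl)c1)c1cccc(NS(=O)(=O)c2cnc(O)nc2O)c1` — a functional assay on A549 cells (Homo sapiens) for antiproliferative activity, read by MTT assay, with a stated time of 24 h (a higher number here means a weaker inhibitor, a lower number a stronger inhibitor), 6640 nM
compound 2 `Cc1ccccc1NNC(=O)c1ccccc1NS(=O)(=O)c1cnc(O)nc1O` — > 20000 nM (a limit of the assay, not a number)
compound 3 `O=C(NNC(=O)c1cccc(NS(=O)(=O)c2cnc(O)nc2O)c1)c1ccc(F)cc1` — > 20000 nM (a limit of the assay, not a number)

Compound 2 sits at the weak end of the three values shown; its value is a limit, and the limit of > 20000 nM in this assay, at which 2 of the 3 values shown sit, holds two of the three entries, so compound 2 cannot be placed relative to compound 3 and lies beyond compound 1 only by an unresolved amount.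

The step to compound 4 `O=C(NNC(=O)c1ccccc1NS(=O)(=O)c1cnc(O)nc1O)c1ccc(F)cc1` is (4-fluorophenyl)carbonyl in place of 2-methylphenyl on an amine nitrogen. Among the measured compounds shown here, the one measured step with the same entering group on the same kind of nitrogen is an at least 3.0-fold higher number from compound 1 to compound 3 (0.47 log units; beyond the scatter), which ran toward a weaker inhibitor and ended at the limit. That step started from a compound with a number; compound 2 already starts at the limit. The expected step that the limit leaves unreadable from compound 2 to compound 4 in this assay is therefore no gain, with the number most likely remaining a limit. Compound 4 is estimated at 40000 nM, range 15000 nM to 150000 nM, and a further limit reading is the expected outcome.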

Compound 4, half-maximal inhibitory concentration: > 20000 nM
Compound 4: only a limit was reported; the forecaster's own chance of this, stated with the estimate: 85%; the middle value lies beyond the limit too.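

No step can be read from compound 2 to compound 4, since both values are limits of the assay: the limit of > 20000 nM in this assay, at which 3 of the 4 values shown sit.

The compounds shown leave open whether (4-fluorophenyl)carbonyl in place of 2-methylphenyl on the amine nitrogen changes activity, and how far compound 2, compound 3 and compound 4 lie from one another.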